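Trifluoromethyl for methyl in a series held at a limit

The compounds below may be only part of what the source reports. "The series", "measured", "known", "first", "only" and "open" are said of these compounds alone.

In a functional assay on P388 cells (Mus musculus) for inhibition (a higher number here means a weaker inhibitor, a lower number a stronger inhibitor), compound 3 `Cc1ccc(/C=C/c2ccc3ccccc3c2)cc1` gives only a limit, > 5000 nM. Compound 1 `CC(=O)Oc1ccc(/C=C/c2ccc3ccccc3c2)cc1` likewise gives only a limit, > 5000 nM. Compound 2 `COc1ccc(/C=C/c2ccc3ccccc3c2)cc1` also gives only a limit, > 5000 nM. The three therefore stand together at the limit of > 5000 nM in this assay, at which 3 of the 3 values shown sit. Compound 4 `FC(F)(F)c1ccc(/C=C/c2ccc3ccccc3c2)cc1` carries trifluoromethyl in place of methyl on an aromatic carbon, para to a large group (trifluoromethyl in place of methyl on an aromatic carbon). The measured changes at that carbon are a step that the two limits leave unreadable from compound 1 to compound 3 and a step that the two limits leave unreadable from compound 2 to compound 3, alongside a step that the two limits leave unreadable from compound 1 to compound 2. None of them gives a size, so they suggest no direction. The expected change is a step that the limit leaves unreadable from compound 3 to compound 4, with nothing foreseen beyond the scatter. Compound 4 is estimated at 8000 nM, with an expected range of 3000 nM to 20000 nM.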

Compound 4, half-maximal inhibitory concentration: > 5000 nM
Compound 4 gave a limit, no number (the forecaster's own chance of this, stated with the estimate: 85%); the middle value lies beyond the limit too.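

The steps from compound 1, compound 2 and compound 3 to compound 4 cannot be read, as all four stand at one limit: the limit of > 5000 nM in this assay, at which 4 of the 4 values shown sit.

The compounds shown leave open whether trifluoromethyl, methyl, methoxy and acetoxy differ at all in this assay.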